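The source may report more compounds than this note shows. Statements on the series, on what has been measured and on what is new or still open speak of the compounds shown alone.

Compound 1 `[N-]=[N+]=Nc1c(F)c(N)c2c(=O)cc(-c3ccc(N)c(F)c3)oc2c1F`: in a functional assay on HeLa cells (Homo sapiens) for cytotoxicity, read by neutral red uptake, with a stated time of 3 days (a higher number here means a weaker inhibitor, a lower number a stronger inhibitor), compound 1 gives 1200 nM.
Compound 2 `CCCCCCCCCC(=O)OCc1c(F)c(N)c2c(=O)cc(-c3ccc(N)c(F)c3)oc2c1F`: in this assay compound 2 gives > 100000 nM, which is a limit of the assay and not a number.

Within the data shown here, compound 2 therefore stands at the limit of > 100000 nM in this assay, at which 1 of the 2 values shown sits, and no measured step connects it to compound 1. Compound 3 `CCCCCCOCc1c(F)c(N)c2c(=O)cc(-c3ccc(N)c(F)c3)oc2c1F` differs from compound 2 by hexyl in place of nonylcarbonyl on an oxygen on a saturated carbon. Among the measured compounds shown here, with no measured step of this kind to lean on, the move from compound 2 to compound 3 is expected to remain near the limit, a change at most modest and possibly none beyond the scatter. For compound 3 the estimated value in this assay is 50000 nM, within 8000 nM to 150000 nM, which means an expected step of an at least 2.0-fold lower number from compound 2 to compound 3 (0.30 log units; that floor lies within the scatter).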

Compound 3, half-maximal inhibitory concentration: > 100000 nM
Compound 3 was reported as a limit; the forecaster's own chance of this, stated with the estimate: 45%; middle value at least 2.0-fold (0.30 log units) away from the limit.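

In this assay compound 3 gives > 100000 nM, which is a limit of the assay and not a number. An ether carrying hexyl thus ends at the same limit as the ester carrying nonylcarbonyl, and the step between these two compounds cannot be read: the limit of > 100000 nM in this assay, at which 2 of the 3 values shown sit.

With (hexyloxy)methyl in place of azido on an aromatic carbon, the change is an at least 83-fold higher number from compound 1 to compound 3 (1.92 log units; beyond the scatter). Going by these compounds, whether a shorter chain, such as methyl or ethyl, on that oxygen would give a readable value stays open. So does the result of an amine or a carboxylic acid at the end of the chain.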